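Swapping Methyl for Fluoro on the Phenol Ring

The source may report more compounds than this note shows. Statements on the series, on what has been measured and on what is new or still open speak of the compounds shown alone.

Compound 3 `Cc1ccc(O)c(/C=N\NC(=O)c2oc3cccc(O)c3c2C)c1` stands second highest of three numbers in a functional assay on MGC-803 cells (Homo sapiens) for inhibition, read by MTT assay (on this read-out lower numbers stand for stronger inhibition and higher numbers for weaker inhibition), where compound 3 gives 5990 nM. Compound 1 `Cc1c(C(=O)N/N=C\c2ccccc2O)oc2cccc(O)c12` gives 10600 nM and compound 2 `Cc1c(C(=O)N/N=C\c2cccc(O)c2O)oc2cccc(O)c12` gives 5030 nM; the steps of a 1.8-fold lower number from compound 1 to compound 3 (0.25 log units; within the scatter) and a 1.2-fold higher number from compound 2 to compound 3 (0.08 log units; within the scatter) both lie within the scatter, while a 2.1-fold lower number from compound 1 to compound 2 (0.32 log units; beyond the scatter) is modest. Compound 4 `Cc1c(C(=O)N/N=C\c2cc(F)ccc2O)oc2cccc(O)c12` differs from compound 3 by fluoro in place of methyl on an aromatic carbon, on an aromatic carbon of a six-membered aromatic ring of carbon only, para to a hydroxy group. Among the compounds with values here, the only measured step touching that carbon, a 1.8-fold lower number from compound 1 to compound 3 (0.25 log units; within the scatter), was within the scatter, so no step beyond the scatter is expected here, as a 1.2-fold higher number from compound 3 to compound 4 (0.07 log units; within the scatter). Compound 4 is therefore estimated at 7000 nM, between 3000 nM and 16000 nM.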

Compound 4, half-maximal inhibitory concentration: 5230 nM
Compound 4: middle estimate off by 1.3-fold (0.13 log units), on the high side; measured number inside the range.
By their numbers in this assay, from the lowest: compounds 2, 4, 3 and 1 (each within the scatter of the next, the first and the last beyond it).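

In this assay, fluoro and methyl on this carbon, para to a hydroxy group, cannot be told apart (a 1.1-fold lower number from compound 3 to compound 4 (0.06 log units; within the scatter)). Fluoro in place of hydrogen gives a modest step beyond the scatter (a 2.0-fold lower number from compound 1 to compound 4 (0.31 log units; beyond the scatter)), where methyl's step stayed within it, and the 5-fluoro-2-hydroxyphenyl compound cannot be told apart from the 2,3-dihydroxyphenyl one (a 1.0-fold higher number from compound 2 to compound 4 (0.02 log units; within the scatter)). No evidence at hand bears on why.

On these data alone, what an amine, a methoxy group or a carboxylic acid would do on this carbon stays open. So does whether fluoro on this carbon would change the number for the 2,3-dihydroxyphenyl compound.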